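Aminoamino in Place of 4-Chlorophenyl on the Carbonyl

A few compounds are considered here, and "the series" means these few. Any claim that something is new, unique, unknown or untested is made for them only; others in the source may bear on it.

Measured so far:
compound 1 `O=[N+]([O-])c1ccc2[nH]c(CSCc3nc4cc([N+](=O)[O-])ccc4[nH]3)nc2c1`: 2410 nM
compound 2 `O=C(CSCc1nc2cc([N+](=O)[O-])ccc2[nH]1)c1ccc(Cl)cc1`: 2230 nM
compound 3 `NC(=O)CSCc1nc2cc([N+](=O)[O-])ccc2[nH]1`: 17200 nM

All three were tested in a functional assay on HCT-116 cells (Homo sapiens) for cytotoxicity, read by MTT assay, with a stated time of 48 h; on this read-out lower numbers stand for stronger inhibition and higher numbers for weaker inhibition. Compound 2 gives the lowest number of the three; compound 1 sits within the scatter of it, so the two cannot be told apart, while compound 3 lies well beyond the scatter from compound 2.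

Compound 4 `NNC(=O)CSCc1nc2cc([N+](=O)[O-])ccc2[nH]1` has not yet been measured. It differs from compound 2 in one place: aminoamino in place of 4-chlorophenyl on a carbonyl carbon. Within the data shown here, the one measured step that bears on this is the move from compound 2 to compound 3, where an amino group took the place of the same 4-chlorophenyl on the same carbonyl carbon: a 7.7-fold higher number from compound 2 to compound 3 (0.89 log units; beyond the scatter). The group entering in compound 4 is likewise small and carries hydrogen-bond donors rather than a ring, so a step of similar direction and size is expected, though nothing measured tells whether the extra nitrogen changes that.

Compound 4 is therefore expected to give about 13000 nM, with a likely range from 5000 nM to 35000 nM. This estimate means an expected step of a 5.8-fold higher number from compound 2 to compound 4 (0.77 log units; beyond the scatter).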

Compound 4, half-maximal inhibitory concentration: 5330 nM
Compound 4: middle estimate off by 2.4-fold (0.39 log units), on the high side; the measured number falls inside the stated range.
By their numbers in this assay, from the lowest: compounds 2 and 1 (each within the scatter of the next); then compound 4; then compound 3.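

In this assay, small groups without a ring do not all carry the same penalty when they replace the 4-chlorophenyl on this carbonyl carbon: aminoamino gives a smaller rise (a 2.4-fold higher number from compound 2 to compound 4 (0.38 log units; beyond the scatter)) than amino does (a 7.7-fold higher number from compound 2 to compound 3 (0.89 log units; beyond the scatter)). The result also gives the first direct view of the amide-type nitrogen, where amino in place of one hydrogen changes the number (a 3.2-fold lower number from compound 3 to compound 4 (0.51 log units; beyond the scatter)), so a change of a single group at this end of the molecule is enough to move the reading by more than the scatter. Compound 4 still does not reach compound 2, so among these three compounds the 4-chlorophenyl ketone gives the lowest number, yet much of the loss seen with compound 3 is recovered without any ring.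

On these data alone, it remains open whether a methyl or a longer chain on that same nitrogen would lower the number further or raise it, and whether a plain phenyl would match the 4-chlorophenyl on the carbonyl carbon. No measurement shown here explains why the added nitrogen shifts the number.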